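Swapping a carbamoyl group on a blood inhibitor

The compounds below may be only part of what the source reports. "The series", "measured", "known", "first", "only" and "open" are said of these compounds alone.

Compound 1 (`O=C(O)COc1ccc(OCc2ccc3ccccc3n2)cc1C1(c2ccccc2)CC2CCC1C2`) gives > 3000 nM as a limit
Compound 2 (`c1ccc(C2(c3cc(OCc4ccccn4)ccc3OCc3ccccn3)CC3CCC2C3)cc1`) gives 275 nM as a measured number
Compound 3 (`O=C(Nc1cccnc1)Oc1ccc(OCc2ccccn2)c(C2(c3ccccc3)CC3CCC2C3)c1`) gives > 3000 nM as a limit

These values come from a functional assay on blood (Homo sapiens) for inhibition; a lower number here means a stronger inhibitor, a higher number a weaker inhibitor. Compound 3 gives > 3000 nM here, which is a limit and not a number. It therefore shares its place with compound 1, and the limit of > 3000 nM in this assay, at which 2 of the 3 values shown sit, sums up that position. Only compound 2 has a true number on this scale.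

The next compound to be tested is compound 4 (`c1ccc(C2(c3cc(OCc4ccc5occc5n4)ccc3OCc3ccccn3)CC3CCC2C3)cc1`). The change is a group of 10 heavy atoms (8 carbon, 1 nitrogen, 1 oxygen; one five-membered aromatic ring with 1 hetero atom, one six-membered aromatic ring with 1 hetero atom) in place of a group of 9 heavy atoms (6 carbon, 2 nitrogen, 1 oxygen; one six-membered aromatic ring with 1 hetero atom), on an oxygen on an aromatic ring and it removes the (pyridin-3-yl)carbamoyl group. Within the data shown here, the one measured step that bears on this is an at least 10-fold higher number from compound 2 to compound 3 (1.03 log units; beyond the scatter) and it is large. That step brought the same group in and took (pyridin-2-yl)methyl out. Taking it out again should therefore move the number down, toward the level of compound 2 at 275 nM in this scale. Among the measured compounds shown here, the entering group is not the one in compound 2, and a single step is thin support, so the expectation stays wide.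

The expected change is an at least 10-fold lower number from compound 3 to compound 4 (1.00 log units; beyond the scatter) on this estimate. Compound 4 is expected to give about 300 nM in this assay with an estimated range from 80 nM to 1200 nM around it.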

Compound 4, half-maximal inhibitory concentration: 80 nM
Estimate against measurement, compound 4: 3.8-fold (0.57 log units) above; the measured number falls inside the stated range.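

In this assay, going by these compounds, replacing the (pyridin-3-yl)carbamoyl on this oxygen on an aromatic ring gives an at least 37-fold lower number from compound 3 to compound 4 (1.57 log units; beyond the scatter), though compound 3 has only a limit there, so the true size of this step stays unknown. Among these compounds, what the earlier compounds did not show is that this place can hold more than the pyridine ring of compound 2: a larger group, with one five-membered and one six-membered aromatic ring, gives a 3.4-fold lower number from compound 2 to compound 4 (0.54 log units; beyond the scatter), a modest change but a real one. Compound 4 thus provides a second true number on the scale and stands well apart from the compounds that reach only a limit: the limit of > 3000 nM in this assay, at which 2 of the 4 values shown sit.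

The compounds shown cannot tell whether the gain comes from the added five-membered ring, from its oxygen, or simply from the larger size of the group. Nor do they show how this place would respond to a group of a different kind, such as a plain benzyl or a morpholine on the same chain carbon.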